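Swapping a Fused Ring for a Small Triazole

This account rests on a few compounds, and the source may have more. Where it says the series, first, only, none or still open, it means among the compounds named here.

Measured so far:
Compound 1, `Cc1ccc2oc(SCC(=O)Nc3ccc(-c4nc(-c5ccccc5)c(-c5ccccc5)n4C)cc3)nc2c1`, gives 65.1% in a functional assay on MCF7 cells (Homo sapiens) for cytotoxicity, read by MTT assay, with a stated time of 24 h, tested at 80 ug/mL; a higher number here means a stronger effect of the compound at the concentration tested, a lower number a weaker effect.
Compound 2, `Cn1c(-c2ccc(NC(=O)CSc3nc4ccccc4s3)cc2)nc(-c2ccccc2)c1-c1ccccc1`, gives 76.6% in this assay.

Compound 2 stands highest of the two numbers, with compound 1 the nearest and lower by a step beyond the scatter. Among the measured compounds shown here, the only measured step, a number 11.5 percentage points higher from compound 1 to compound 2 (beyond the scatter), changes the ring attached to the same sulfur, so it is the one comparison that bears on what follows, though it exchanges one fused bicyclic ring for another and never removes the six-membered carbon ring.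

Compound 3, `Cn1cnnc1SCC(=O)Nc1ccc(-c2nc(-c3ccccc3)c(-c3ccccc3)n2C)cc1`, is compound 2 with a different group on that sulfur: 4-methyl-4H-1,2,4-triazol-3-yl in place of 1,3-benzothiazol-2-yl on a sulfur. The measured step shows that this position tolerates change and can shift the read-out modestly. For the measured compounds named here, no measured pair shows the loss of the fused benzene, so the direction rests on the general observation that a smaller group stands in for a larger one. A modest decrease is therefore expected, a number 14.6 percentage points lower from compound 2 to compound 3 (beyond the scatter), though the scatter leaves room for no change. For compound 3 the estimated value is 62%, within a range from 40% to 82%.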

Compound 3, a percentage reported as activity, at one concentration (the size of the read-out at that concentration, not a potency): 89.3%
Compound 3: the middle estimate sits 27.3 percentage points below what was measured; measured number outside the range, above it.
By their numbers in this assay, from the lowest: compound 1; then compound 2; then compound 3.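

At the sulfur, a fused ring is not needed for a strong read-out in this assay: 4-methyl-4H-1,2,4-triazol-3-yl, one five-membered aromatic ring with 6 heavy atoms, replaces 1,3-benzothiazol-2-yl with 9 and gives a number 12.7 percentage points higher from compound 2 to compound 3 (beyond the scatter), the opposite of what a smaller group might have suggested. Measured against 5-methyl-1,3-benzoxazol-2-yl, the same triazole gives a number 24.2 percentage points higher from compound 1 to compound 3 (beyond the scatter), so among these three compounds both groups carrying a six-membered carbon ring read lower, and none of the three goes against this. Nothing at hand explains why the triazole compound reads highest.

The compounds shown leave open which feature of the triazole matters, since the methyl group on it is never removed or replaced, for instance by a hydrogen, an ethyl group or a longer chain, and no amine or carboxylic acid is shown on that ring. Each number also comes from one concentration, so these results show only a stronger or weaker effect at that concentration.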